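Working notes: replacing pyridin-2-yl in compound 3

The source may report more compounds than this note shows. Statements on the series, on what has been measured and on what is new or still open speak of the compounds shown alone.

Measured in a functional assay on DU-145 cells (Homo sapiens) for inhibition, read by trypan blue exclusion, with a stated time of 72 h; a lower number here means a stronger inhibitor, a higher number a weaker inhibitor:
- compound 1 `Cn1c(=O)c(S(=O)(=O)c2ccc(F)cc2F)cc2cnc(Nc3ccc4occc4c3)nc21`: 15000 nM
- compound 2 `Cn1c(=O)c(S(=O)(=O)c2ccccc2)cc2cnc(Nc3ccc4cc[nH]c4c3)nc21`: 10000 nM
- compound 3 `Cn1c(=O)c(S(=O)(=O)c2ccc(F)cc2F)cc2cnc(Nc3ccccn3)nc21`: 75000 nM

Compound 3 has the highest number of the three in this assay, at 75000 nM. The next structure, compound 4 `Cn1c(=O)c(S(=O)(=O)c2ccc(F)cc2F)cc2cnc(Nc3ccc4cc[nH]c4c3)nc21`, has 1H-indol-6-yl in place of pyridin-2-yl on a nitrogen on an aromatic ring.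

Within the data shown here, one measured step bears directly on this place. With the sulfonyl group of compound 4 retained, the pyridin-2-yl group replaced 1-benzofuran-5-yl, giving a 5.0-fold higher number from compound 1 to compound 3 (0.70 log units; beyond the scatter). The reverse direction therefore points to a lower number when a two-ring group returns. Compound 2 already carries 1H-indol-6-yl and gives 10000 nM, but its sulfonyl group differs, and the effect of that difference has not been measured on its own.

A step beyond the scatter towards a lower number is expected, estimated as a 6.8-fold lower number from compound 3 to compound 4 (0.83 log units; beyond the scatter). The expected value for compound 4 is 11000 nM, with an estimated range of 4000 nM to 30000 nM.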

Compound 4, half-maximal inhibitory concentration: 5000 nM
Compound 4: middle estimate off by 2.2-fold (0.34 log units), on the high side; measured number inside the range.
By their numbers in this assay, from the lowest: compounds 4, 2 and 1 (each within the scatter of the next, the first and the last beyond it); then compound 3.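

In this assay, the group on the amino nitrogen now shows a large effect with the 2,4-difluorophenyl sulfonyl group held constant: 1H-indol-6-yl in place of pyridin-2-yl gives a 15-fold lower number from compound 3 to compound 4 (1.18 log units; beyond the scatter), and the two two-ring groups also separate, with 1H-indol-6-yl in place of 1-benzofuran-5-yl giving a 3.0-fold lower number from compound 1 to compound 4 (0.48 log units; beyond the scatter). The sulfonyl difference, unresolved until now, can be read on its own: 2,4-difluorophenyl in place of phenyl gives a 2.0-fold lower number from compound 2 to compound 4 (0.30 log units; within the scatter), so this change does not distinguish the two compounds. No supporting data bear on the origin of these steps.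

The compounds shown leave open how an amine or a carboxylic acid carried on the 1H-indol-6-yl group would affect the number. Going by these compounds, a longer chain on that group is equally open.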